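Chloro to fluoro exchange on two related cores

The compounds below may be only part of what the source reports. "The series", "measured", "known", "first", "only" and "open" are said of these compounds alone.

Measured compounds in a functional assay on WiDr cells (Homo sapiens) for inhibition, read by sulforhodamine B assay, with a stated time of 48 h; a lower number here means a stronger inhibitor of growth, a higher number a weaker inhibitor of growth:
compound 1 `CC(=O)OC/C(=C\c1ccc(Cl)cc1)C(=O)c1ccccc1` gives 4800 nM
compound 2 `CC(=O)OC/C(=C\c1ccc(F)cc1)C(=O)c1ccccc1` gives 13000 nM
compound 3 `C=C(C/C(=C\c1ccc(Cl)cc1)C(=O)c1ccccc1)C(=O)c1ccccc1` gives 20000 nM

Compound 4 `C=C(C/C(=C\c1ccc(F)cc1)C(=O)c1ccccc1)C(=O)c1ccccc1` is not yet measured. Compound 4 differs from compound 3 by fluoro in place of chloro on an aromatic carbon. The difference between the core of compound 1 and the core of compound 3 is not broken down here.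

The same change has one precedent: compound 2 differs from compound 1 by fluoro in place of chloro on an aromatic carbon, and in this assay this gave a 2.7-fold higher number from compound 1 to compound 2 (0.43 log units; beyond the scatter). Compound 3 already gives the highest number of the three.

An expected step of a 2.5-fold higher number from compound 3 to compound 4 (0.40 log units; beyond the scatter) rests on the earlier step of a 2.7-fold higher number from compound 1 to compound 2 (0.43 log units; beyond the scatter) in this assay, transferred to the other core. Compound 4 is therefore estimated at 50000 nM in this assay, with the range 18000 nM to 140000 nM; a limit rather than a number is possible.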

Compound 4, concentration for 50% growth inhibition: 19000 nM
Compound 4: middle estimate off by 2.6-fold (0.42 log units), on the high side; the range from low to high includes it.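

In this assay, fluoro in place of chloro on the core of compound 3 gives a 1.1-fold lower number from compound 3 to compound 4 (0.02 log units; within the scatter) and so leaves no readable change on this core. The two cores do not respond alike to this exchange: the same change on two cores in this assay, a 2.7-fold higher number (0.43 log units; beyond the scatter) from compound 1 to compound 2 and a 1.1-fold lower number (0.02 log units; within the scatter) from compound 3 to compound 4, 2.9-fold (0.45 log units) apart, beyond the scatter of two such steps. This shows that the step seen on the core of compound 1 cannot be carried across as a fixed increment in this series, but with one pair per core it does not show what in the cores sets the steps apart or how a further core would respond.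

Open, on these data alone, is whether bromo, methoxy or an amine on the same aromatic carbon would also separate the two cores. Also open, as far as these compounds go, is whether hydrogen there would give a common reference for both.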